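The source may hold more compounds than are shown below. What is called first, only, known or untested is meant among the compounds shown, and "the series" means these compounds.

Measured compounds:
compound 1, `N#Cc1cn([C@H]2C[C@H](O)[C@@H](CO)O2)c2ncnc(N)c12`, 25000 nM;
compound 2, `N#Cc1cn(C2OC(CO)CC2O)c2ncnc(N)c12`, 4000 nM;
compound 3, `N#Cc1cn(C2C=CC(CO)O2)c2ncnc(N)c12`, 176000 nM.

In a functional assay on KB cells (Homo sapiens) for inhibition (a higher number here means a weaker inhibitor, a lower number a stronger inhibitor), compound 1 gives the second highest of the three numbers. Compound 2 sits nearest to it, with a lower number that lies beyond the scatter, while compound 3 lies furthest away, with a higher number that is also beyond the scatter. Compound 1 therefore occupies the middle ground among these three.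

Compound 4, `N#Cc1cn([C@@H]2O[C@H](CO)[C@@H](O)[C@@H]2N)c2ncnc(N)c12`, is the compound that has not yet been measured. It differs from compound 1 in one place: amino in place of hydrogen on a saturated ring carbon. Within the data shown here, no pair of measured compounds shows this same change, so there is no step from which the size of the effect can be read directly. The three measured numbers show only that alterations on the five-membered non-aromatic ring move the result in this assay by amounts beyond the scatter in either direction.

For compound 4 the step of a 1.7-fold lower number from compound 1 to compound 4 (0.22 log units; within the scatter) is expected to be small, toward a somewhat lower number, but possibly within the scatter. Compound 4 is thus estimated at 15000 nM, with a range from 3000 nM to 80000 nM.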

Compound 4, half-maximal inhibitory concentration: 105000 nM
The estimate for compound 4 lay 7.0-fold (0.85 log units) below the measured number; the whole stated range lies below it.
By their numbers in this assay, from the lowest: compound 2; then compound 1; then compounds 4 and 3 (each within the scatter of the next).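

In this assay, amino in place of hydrogen on this saturated ring carbon, next to the ring atom that bears a hydroxy group, gives a 4.2-fold higher number from compound 1 to compound 4 (0.62 log units; beyond the scatter). Among these compounds, this is the first single change that can be read directly, and it shows that this ring carbon is not indifferent to substitution: here the amino group goes with a weaker inhibitor, not the small shift a single added atom might suggest. No measurement shown here accounts for the step.

The compounds shown cannot say whether this weakening belongs to the amino group itself or would follow any group at this carbon, such as fluorine, methoxy or dimethylamino. Nor do they show whether the step keeps its direction on a ring without the hydroxy group.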